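The source may report more compounds than this note shows. Statements on the series, on what has been measured and on what is new or still open speak of the compounds shown alone.

Measured so far in a functional assay on K562 cells (Homo sapiens) for cytotoxicity, read by trypan blue exclusion, with a stated time of 96 h; a lower number here means a stronger inhibitor, a higher number a weaker inhibitor
compound 1 `COc1ccc(NS(=O)(=O)/C=C/c2ccc(OC)cc2OC)cc1` gives 15000 nM
compound 2 `COc1ccc(NS(=O)(=O)/C=C/c2c(OC)cccc2OC)cc1` gives 5000 nM
compound 3 `COc1ccc(NS(=O)(=O)/C=C/c2c(OC)cc(OC)cc2OC)cc1` gives 75 nM

Compound 3 has the lowest of these three numbers. Compound 4 `COc1ccc(NS(=O)(=O)/C=C/c2c(OC)cc(O)cc2OC)cc1` differs from it in one place, with hydrogen in place of methyl on an oxygen on an aromatic ring, a change of methoxy to hydroxy (hydrogen in place of methyl on an oxygen on an aromatic ring). Among the measured compounds shown here, no measured step makes this exact change. The closest evidence is the large 67-fold lower number from compound 2 to compound 3 (1.82 log units; beyond the scatter), which brings in the same methoxy that compound 4 alters. The also large a 200-fold lower number from compound 1 to compound 3 (2.30 log units; beyond the scatter) brings in a different methoxy. Compound 4 keeps that oxygen, so a smaller rise in this assay is expected than the one the first of these steps implies on losing the whole group. The expected change is a 6.7-fold higher number from compound 3 to compound 4 (0.82 log units; beyond the scatter) toward a higher number. Compound 4 is estimated at 500 nM with an expected range from 100 nM to 3000 nM in this measure.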

Compound 4, half-maximal inhibitory concentration: 10000 nM
Estimate against measurement, compound 4: 20-fold (1.30 log units) below; the measured number lies above the stated range.
By their numbers in this assay, from the lowest: compound 3; then compounds 2, 4 and 1 (each within the scatter of the next, the first and the last beyond it).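

In this assay, the methyl on this oxygen proves to matter by itself, with a 130-fold higher number from compound 3 to compound 4 (2.12 log units; beyond the scatter) on the change of methoxy to hydroxy. Keeping the oxygen recovers nothing beyond the scatter: hydroxy in place of hydrogen on the aromatic carbon gives a 2.0-fold higher number from compound 2 to compound 4 (0.30 log units; within the scatter) for this change. No measurement shown bears on the reason for this loss.

The compounds shown leave open whether ethoxy, a longer chain on this oxygen, would hold the number of compound 3. They also leave open how an amine at this place would compare with hydroxy.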